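This account rests on a few compounds, and the source may have more. Where it says the series, first, only, none or still open, it means among the compounds named here.

In an assay on isolated protein for agonist activity at Bile acid receptor (Homo sapiens), read by AlphaScreen, with a stated time of 30 min (on this read-out lower numbers stand for smaller maximal responses and higher numbers for larger maximal responses), the three measured compounds give:

compound 1 `Cc1ccccc1-n1nc(C)c2c1NC(=O)[C@H](C)S[C@@H]2c1ccc(-c2ccccc2)cc1`: 24%
compound 2 `Cc1nn(-c2ccccc2C(F)(F)F)c2c1C(c1ccc(Oc3ccccc3)cc1)SC(C)C(=O)N2`: 50%
compound 3 `Cc1nn(-c2ccccc2Br)c2c1C(c1ccc(Oc3ccccc3)cc1)SC(C)C(=O)N2`: 84%

Compound 1 stands lowest of the three; compound 2 lies beyond the scatter above it and compound 3 further still. Compound 4 `Cc1ccccc1-n1nc(C)c2c1NC(=O)[C@H](C)S[C@@H]2c1ccc(-c2ccco2)cc1` differs from compound 1 by furan-2-yl in place of phenyl on an aromatic carbon. Within the data shown here, the only measured step, a number 34 percentage points higher from compound 2 to compound 3 (beyond the scatter), concerns a different substituent on a different ring and so bears little on this change; no measured pair exchanges phenyl for furan-2-yl. With nothing pointing either way, no step beyond the scatter is expected, the expected step being a number 4 percentage points higher from compound 1 to compound 4 (within the scatter). Compound 4 is therefore estimated at 28%, within a range of 10% to 55%.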

Compound 4, largest response reached (reported as efficacy), in percent of the reference or control that the assay uses: 32%
Compound 4: the middle estimate sits 4 percentage points below what was measured; measured number inside the range.
By their numbers in this assay, from the lowest: compounds 1 and 4 (each within the scatter of the next); then compound 2; then compound 3.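

In this assay the change to furan-2-yl in place of phenyl gives a number 8 percentage points higher from compound 1 to compound 4 (within the scatter) and so shows that this place, para to a large group, takes a five-membered aromatic ring with 1 hetero atom without a step beyond the scatter. One heavy atom fewer and one hydrogen-bond acceptor more leave the maximal response within the scatter here. No measurement shown bears on the reason for this result.

On these data alone, it remains open whether an amine or a carboxylic acid at this place would move the response beyond the scatter. As far as these compounds go, it also remains open whether furan-2-yl would read the same way on the core of compound 3.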